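Salicylanilide series: nitrile to trifluoromethyl on the anilide ring

The compounds below may be only part of what the source reports. "The series", "measured", "known", "first", "only" and "open" are said of these compounds alone.

Measured so far:
compound 1 `O=C(Nc1cc(C(F)(F)F)cc(C(F)(F)F)c1)c1cc(F)ccc1O`: 620 nM
compound 2 `N#Cc1cccc(NC(=O)c2cc(F)ccc2O)c1`: "not determined" (no result reported)

Compound 1 `O=C(Nc1cc(C(F)(F)F)cc(C(F)(F)F)c1)c1cc(F)ccc1O` gives 620 nM in a functional assay on NALM-6 cells (Homo sapiens) for cytotoxicity, read by luminescence and CellTiter-Glo, with a stated time of 3 days; a higher number here means a weaker inhibitor, a lower number a stronger inhibitor. Compound 2 `N#Cc1cccc(NC(=O)c2cc(F)ccc2O)c1` gives "not determined" (no result reported) in this assay, so it stands nowhere on the numbers shown; compound 1 is the only anchor in the series.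

The next compound is compound 3 `O=C(Nc1cccc(C(F)(F)F)c1)c1cc(F)ccc1O`. The change from compound 2 to compound 3 is trifluoromethyl in place of cyano on an aromatic carbon. With no number for compound 2 in this assay, the size and direction of this step cannot be stated; the expectation for compound 3 rests on compound 1 alone, which carries two trifluoromethyl groups where compound 3 carries one. Compound 3 is expected to come in at about 1500 nM, with a likely range from 400 nM to 6000 nM in this assay.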

Compound 3, half-maximal inhibitory concentration: 1800 nM
For compound 3 the middle estimate is 1.2-fold (0.08 log units) below the measured one, within the range that was stated.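

In this assay the series now has its first readable step, a 2.9-fold higher number from compound 1 to compound 3 (0.46 log units; beyond the scatter), with hydrogen in place of trifluoromethyl on an aromatic carbon. Within the data shown here, the second trifluoromethyl group therefore matters beyond the scatter, yet compound 3 still gives a measurable value with only one such group on the anilide ring. No measurement here bears on why the number moves with this change.

On these data alone, the step from nitrile to trifluoromethyl cannot be read, since compound 2 has no number, so the comparison of these two groups at this position remains open. Also open, as far as these compounds go, is whether an amine, a carboxylic acid or a methoxy group in the place of trifluoromethyl would hold, lower or raise the number on the shared core.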